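The source may hold more compounds than are shown below. What is called first, only, known or untested is meant among the compounds shown, and "the series" means these compounds.

The series consists of two measured compounds and one awaiting measurement. Compound 1, `CC(=O)Nc1cc(OCc2ccccc2)nc(SCc2ccccc2)n1`, was tested in a functional assay on HepG2 cells (Homo sapiens) for antiproliferative activity, read by MTT assay, with a stated time of 72 h (on this read-out higher numbers stand for weaker inhibition of growth and lower numbers for stronger inhibition of growth), where compound 1 gives 42900 nM. Compound 2, `COc1cc(OC)n2cc(-c3ccc([N+](=O)[O-])cc3)nc2n1`, is built on a different core, and in this assay compound 2 gives 35900 nM. Compound 2 thus shows the lower of the two numbers, yet the gap to compound 1 lies within the scatter, so the two values cannot be told apart. Within the data shown here, no single-point step between them exists, as the two structures differ in more than one place. Compound 3, `CNc1ccc(-c2cn3c(OC)cc(OC)nc3n2)cc1`, keeps the core of compound 2 and differs from it in one place: methylamino in place of nitro on an aromatic carbon. Among the measured compounds shown here, no measured pair shows what this exchange does in this assay, so the expected step from compound 2 to compound 3 is taken as small, with no firm direction and probably not beyond the scatter. On that basis compound 3 is expected to give 40000 nM in this assay, the estimated step being a 1.1-fold higher number from compound 2 to compound 3 (0.05 log units; within the scatter). For compound 3 the estimated range is wide, from 10000 nM to 150000 nM, since nothing shown constrains it closely.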

Compound 3, concentration for 50% growth inhibition: > 100000 nM
Compound 3 was reported as a limit (the forecaster's own chance of this, stated with the estimate: 20%); at least 2.5-fold (0.39 log units) between middle value and limit.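

Among these compounds, this is the only single-place exchange, and it shows that in this assay the group on this aromatic carbon, para to a large group, matters: methylamino in place of nitro gives an at least 2.7-fold higher number from compound 2 to compound 3 (0.44 log units; beyond the scatter). Compound 1 and compound 2 differ in more than one place, so their pairing could show nothing of this kind. Compound 3 is reported as a limit and not as a number, so the direction of the step is fixed while its full size remains unknown: the limit of > 100000 nM in this assay, at which 1 of the 3 values shown sits.

The compounds shown do not separate what leaving nitro contributes from what entering methylamino contributes, and a plain amine, a methoxy group or a chlorine atom on this carbon would be needed to tell those contributions apart. They also leave open whether the same exchange would give a step of this direction on a different core, and whether any group at this position could give a lower number than nitro does.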